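An Ethoxycarbonyl Addition on a Shared Core

The compounds below may be only part of what the source reports. "The series", "measured", "known", "first", "only" and "open" are said of these compounds alone.

Compound 1 `CC1CCC(/C=N/c2cccc(C(=O)O)c2)=C2NC=CC(=O)N21` was tested in a functional assay on the whole organism with Rattus norvegicus as the target; on this read-out higher numbers stand for an effect only at larger amounts of compound and lower numbers for an effect already at smaller amounts. In this assay compound 1 reaches only a limit, > 100 umol/kg. Its companion compound 2 `CC1CCC(/C=N/c2ccc(C(=O)O)cc2)=C2NC=CC(=O)N21` likewise reaches only a limit in this assay, > 100 umol/kg. Going by the values given here, both results sit at the limit of > 100 umol/kg in this assay, at which 2 of the 2 values shown sit, so compound 1 stands level with the only other measured compound and no number separates the two. Compound 3 `CCOC(=O)C1=CNC2=C(/C=N/c3cccc(C(=O)O)c3)CCC(C)N2C1=O` has not yet been measured in this assay. It differs from compound 1 in one place: ethoxycarbonyl in place of hydrogen on a double-bonded ring carbon. Among the compounds with values here, no step between two measured compounds is known here, so the size of a step in this assay cannot be read from measured pairs, and no change beyond the usual scatter is expected in either direction. Compound 3 is therefore estimated at 150 umol/kg, within 60 umol/kg to 400 umol/kg, with the step that the limit leaves unreadable from compound 1 to compound 3 expected to be small and a limit again likely.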

Compound 3, dose for 50% inhibition: 100 umol/kg
Estimate against measurement, compound 3: 1.5-fold (0.18 log units) above; the measured number falls inside the stated range.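

In this assay, going by these compounds alone, compound 3 gives 100 umol/kg, the first value that is a number and not a limit. Ethoxycarbonyl in place of hydrogen on a double-bonded ring carbon gives a number no higher from compound 1 to compound 3 (the limit leaves the size open), so this position accepts the group with no rise in the dose needed, though whether the dose falls at all cannot be read. The series still rests largely on limits: the limit of > 100 umol/kg in this assay, at which 2 of the 3 values shown sit.

The compounds shown leave open whether a shorter ester such as methoxycarbonyl, a longer chain on the ester, a carboxylic acid or a primary amide on this ring carbon would give a lower number. They also leave open whether ethoxycarbonyl would have any comparable outcome on the core of compound 2.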